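This account rests on a few compounds, and the source may have more. Where it says the series, first, only, none or still open, it means among the compounds named here.

Measured in a functional assay on A549 cells (Homo sapiens) for antiproliferative activity, read by MTT assay, with a stated time of 72 h; on this read-out higher numbers stand for weaker inhibition and lower numbers for stronger inhibition:
compound 1 `Nc1nc(N)c2cc(CSC(=S)N3CCN(C4CCCCC4)CC3)ccc2n1`: 4710 nM
compound 2 `Nc1nc(N)c2cc(CSC(=S)N3CCN(c4ccc(O)cc4)CC3)ccc2n1`: 4210 nM
compound 3 `Cc1ccccc1N1CCN(C(=S)SCc2ccc3nc(N)nc(N)c3c2)CC1`: 3920 nM

Compound 1 cannot be separated from the other two on these numbers: a 1.1-fold lower number from compound 1 to compound 2 (0.05 log units; within the scatter) and a 1.2-fold lower number from compound 1 to compound 3 (0.08 log units; within the scatter) both lie within the scatter. Compound 4 `Nc1nc(N)c2cc(CSC(=S)N3CCN(c4ccccc4Cl)CC3)ccc2n1` has not yet been measured. It differs from compound 1 by 2-chlorophenyl in place of cyclohexyl on an amine nitrogen in a ring. Those two measured steps change the same place, and the closest replacement is 2-methylphenyl. The remaining step, a 1.1-fold lower number from compound 2 to compound 3 (0.03 log units; within the scatter), is also within the scatter. No step beyond the scatter is therefore expected in this assay. Compound 4 is expected at 3800 nM, within an estimated range of 2000 nM to 7000 nM. The estimated change is a 1.2-fold lower number from compound 1 to compound 4 (0.09 log units; within the scatter).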

Compound 4, half-maximal inhibitory concentration: 3610 nM
Estimate against measurement, compound 4: 1.1-fold (0.02 log units) above, within the range that was stated.
By their numbers in this assay, from the lowest: compounds 4, 3, 2 and 1 (each within the scatter of the next).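

In this assay the 2-chlorophenyl group on the amine nitrogen in the ring stays within the scatter of both cyclohexyl (a 1.3-fold lower number from compound 1 to compound 4 (0.12 log units; within the scatter)) and 4-hydroxyphenyl (a 1.2-fold lower number from compound 2 to compound 4 (0.07 log units; within the scatter)). The new compound adds a change on the aromatic ring itself, chloro in place of methyl on an aromatic carbon, and this too produces no step beyond the scatter (a 1.1-fold lower number from compound 3 to compound 4 (0.04 log units; within the scatter)). No measurement is available that would account for this flat result. The compounds shown leave open whether a carboxylic acid on that aromatic ring, or a longer chain on the amine nitrogen, would move the number beyond the scatter.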